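Swapping an aryl ether for an aryl thioether on a shared core

This account rests on a few compounds, and the source may have more. Where it says the series, first, only, none or still open, it means among the compounds named here.

Compound 1 `Nc1cc(N)c2nc(-c3ccccc3)c(Oc3ccc(Cl)c(Cl)c3)nc2c1` gives 14500 nM in a functional assay on PC-3 cells (Homo sapiens) for inhibition, read by sulforhodamine B assay, with a stated time of 48 h; on this read-out lower numbers stand for stronger inhibition of growth and higher numbers for weaker inhibition of growth. Compound 2 `Nc1cc(N)c2nc(-c3ccccc3)c(Sc3ccc(F)cc3)nc2c1` reaches only a limit in this assay, < 100000 nM. Compound 3 `Nc1cc(N)c2nc(-c3ccccc3)c(Oc3ccc(F)cc3)nc2c1` gives 27500 nM in this assay.

Compound 3 carries the higher of the two numbers, with compound 1 nearest; the step of a 1.9-fold higher number from compound 1 to compound 3 (0.28 log units; within the scatter) stays within the scatter. Compound 4 `Nc1cc(N)c2nc(-c3ccccc3)c(Sc3ccc(Cl)c(Cl)c3)nc2c1` is not yet measured and differs from compound 3 in one place: (3,4-dichlorophenyl)sulfanyl in place of 4-fluorophenoxy on an aromatic carbon. The exchange of phenyl groups on oxygen, a 1.9-fold higher number from compound 1 to compound 3 (0.28 log units; within the scatter), was small. The exchanges between phenoxy and phenylsulfanyl, a step that the limit leaves unreadable from compound 1 to compound 2 and a step that the limit leaves unreadable from compound 2 to compound 3, cannot be read because compound 2 sits at the limit of < 100000 nM in this assay, at which 1 of the 3 values shown sits. From compound 3 to compound 4 no step beyond the scatter is expected, a 1.8-fold lower number from compound 3 to compound 4 (0.26 log units; within the scatter). Compound 4 is therefore estimated at 15000 nM, between 5000 nM and 50000 nM.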

Compound 4, concentration for total growth inhibition: 15500 nM
Compound 4: middle estimate off by 1.0-fold (0.01 log units), on the low side; the measured number falls inside the stated range.
By their numbers in this assay, from the lowest: compounds 1, 4 and 3 (each within the scatter of the next).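

A matched pair now exists at this position with the 3,4-dichlorophenyl group held fixed: in this assay, exchanging the linking oxygen for sulfur gives a 1.1-fold higher number from compound 1 to compound 4 (0.03 log units; within the scatter). Changing the linking atom and the ring substituents together gives a 1.8-fold lower number from compound 3 to compound 4 (0.25 log units; within the scatter), so neither exchange moves the number beyond the scatter. The steps involving compound 2 cannot be read: the limit of < 100000 nM in this assay, at which 1 of the 4 values shown sits.

As far as these compounds go, it remains open whether the same oxygen-for-sulfur exchange behaves alike with the 4-fluorophenyl group. From the compounds shown here alone, it is also open whether an amine or a carboxylic acid on this aromatic carbon would move the number beyond the scatter.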